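Isoflavone ether series: chain variation at the aryl oxygen

The compounds below may be only part of what the source reports. "The series", "measured", "known", "first", "only" and "open" are said of these compounds alone.

Measured compounds:
compound 1, `CCOc1ccc2c(=O)c(-c3ccc(O)cc3)coc2c1`, 100%
compound 2, `O=c1c(-c2ccc(O)cc2)coc2cc(OCCCCBr)ccc12`, 98.3%
compound 3, `O=c1c(-c2ccc(O)cc2)coc2cc(OCCC3OCCCO3)ccc12`, 88.5%

The read-out is a functional assay on mitochondria (Cricetulus griseus) for inhibition of Monoamine oxidase (Homo sapiens), tested at 9 uM; a higher number here means a stronger effect of the compound at the concentration tested, a lower number a weaker effect. Compound 3 stands lowest of the three numbers in this assay: its gap to compound 2 is within the scatter, as the step of a number 9.8 percentage points lower from compound 2 to compound 3 (within the scatter) shows, while its gap to compound 1 is beyond it, as the step of a number 11.5 percentage points lower from compound 1 to compound 3 (beyond the scatter) shows.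

Compound 4, `O=C(O)CCCCCCCCCOc1ccc2c(=O)c(-c3ccc(O)cc3)coc2c1`, has not yet been measured in this assay. The change from compound 3 is a group of 10 heavy atoms (8 carbon, 2 oxygen; no ring) in place of a group of 6 heavy atoms (4 carbon, 2 oxygen; one six-membered non-aromatic ring with 2 hetero atoms), on a saturated chain carbon, two bonds along the chain from an oxygen on an aromatic ring. All three measured steps touch the same place, the saturated chain carbon two bonds along the chain from an oxygen on an aromatic ring. The step of a number 1.7 percentage points lower from compound 1 to compound 2 (within the scatter) was flat, the step of a number 11.5 percentage points lower from compound 1 to compound 3 (beyond the scatter) modest, the step of a number 9.8 percentage points lower from compound 2 to compound 3 (within the scatter) within the scatter. Nothing measured carries a 7-carboxyheptyl or any group of this length, so the expectation rests on the tolerance at this position seen so far. Compound 4 is expected to stay close to compound 3, with the estimated step of a number 3.5 percentage points lower from compound 3 to compound 4 (within the scatter) not beyond the scatter. For compound 4 the estimate in this assay is 85%, ranging from 60% to 100%.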

Compound 4, a percentage reported as inhibition, at one concentration (the size of the read-out at that concentration, not a potency): 95%
The estimate for compound 4 lay 10 percentage points below the measured number, within the range that was stated.
By their numbers in this assay, from the lowest: compounds 3, 4, 2 and 1 (each within the scatter of the next, the first and the last beyond it).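

In this assay, the open 7-carboxyheptyl group, with no ring and with a hydrogen-bond donor that the leaving group lacks, gives a number 6.5 percentage points higher from compound 3 to compound 4 (within the scatter), so replacing the six-membered ring with 2 hetero atoms by this chain produces no change that can be told from the scatter. The carboxylic acid chain also stays within the scatter of the two other ethers, with a number 3.3 percentage points lower from compound 2 to compound 4 (within the scatter) and a number 5 percentage points lower from compound 1 to compound 4 (within the scatter). Among the four compounds, a chain of this length is therefore accepted at the saturated chain carbon, two bonds along the chain from an oxygen on an aromatic ring, at the one concentration tested, and the only step beyond the scatter remains a number 11.5 percentage points lower from compound 1 to compound 3 (beyond the scatter).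

The compounds shown offer no evidence that bears on why the read-out holds up with so large a group. Whether an amine or a longer chain in the same place would keep the read-out stays open, as does how the effect of these compounds would compare at any other concentration.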